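The source may hold more compounds than are shown below. What is called first, only, known or untested is meant among the compounds shown, and "the series" means these compounds.

Measured so far:
- Compound 1, `Nc1ncnc(Oc2ccc(NC(=O)C3(C(=O)Nc4ccc(F)cc4)CC3)cc2F)c1/C=N/O`: in a physicochemical assay for lipophilicity, using the shake flask method (on this read-out lower numbers stand for lower lipophilicity and higher numbers for higher lipophilicity), compound 1 gives 2.62
- Compound 2, `C#CCO/N=C/c1c(N)ncnc1Oc1ccc(NC(=O)C2(C(=O)Nc3ccc(F)cc3)CC2)cc1F`: in this assay compound 2 gives 3.34
- Compound 3, `CC(C)(C)OC(=O)N/N=C/c1c(N)ncnc1Oc1ccc(NC(=O)C2(C(=O)Nc3ccc(F)cc3)CC2)cc1F`: in this assay compound 3 gives 3.7

Compound 3 stands highest of the three: it lies a number 0.36 log units higher from compound 2 to compound 3 (beyond the scatter) and a number 1.08 log units higher from compound 1 to compound 3 (beyond the scatter). All three compounds share the same core and differ only in the group carried by the double-bonded nitrogen. Compound 4, `CCOC(=O)CO/N=C/c1c(N)ncnc1Oc1ccc(NC(=O)C2(C(=O)Nc3ccc(F)cc3)CC2)cc1F`, keeps that core and changes this group once more: (ethoxycarbonyl)methoxy in place of (tert-butoxycarbonyl)amino on a double-bonded nitrogen.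

Among the measured compounds shown here, two measured steps bear on it. Going from a bare hydroxy on that nitrogen to a propargyloxy gave a number 0.72 log units higher from compound 1 to compound 2 (beyond the scatter); replacing that propargyloxy with the (tert-butoxycarbonyl)amino of compound 3 gave a number 0.36 log units higher from compound 2 to compound 3 (beyond the scatter). The change to compound 4 removes the (tert-butoxycarbonyl)amino and installs an oxygen-linked chain of similar size but without a hydrogen-bond donor, so a step back toward the value of compound 2 is expected rather than a further rise. The expected step is a number 0.50 log units lower from compound 3 to compound 4 (beyond the scatter), a modest fall that is still beyond the scatter. For compound 4 in this assay the estimated value is 3.2, with a range from 2.7 to 3.7.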

Compound 4, partition coefficient: 3.15
Compound 4: middle estimate off by 0.05 log units, on the high side; measured number inside the range.
By their numbers in this assay, from the lowest: compound 1; then compounds 4 and 2 (each within the scatter of the next); then compound 3.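

In this assay, the (ethoxycarbonyl)methyl on the oxygen gives a reading above that of the bare hydroxy (a number 0.53 log units higher from compound 1 to compound 4 (beyond the scatter)), so a second chain on this oxygen now stands clear of the starting group, as the propargyl did. The two chains cannot be separated, however (a number 0.19 log units lower from compound 2 to compound 4 (within the scatter)), which means that ethoxycarbonyl in place of ethynyl on that saturated chain carbon gives no readable change in this set. Among the compounds shown here, compound 4 also shows that this position can respond to a swap between chains of similar heavy-atom count (a number 0.55 log units lower from compound 3 to compound 4 (beyond the scatter)), although that swap replaces the nitrogen-linked (tert-butoxycarbonyl)amino, with its hydrogen-bond donor, by an oxygen-linked chain with none, so the single step cannot divide the change between these differences.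

From the compounds shown here alone, how a longer chain, or an amine or a carboxylic acid at the end of the chain on this oxygen, would read in this assay remains open. No measurement given here accounts for any of these differences.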